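The compounds below may be only part of what the source reports. "The series", "measured", "known", "first", "only" and "open" are said of these compounds alone.

Measured compounds in an assay on HEK293 cells for inhibition of Steryl-sulfatase (Homo sapiens), tested at 1 uM; on this read-out higher numbers stand for a stronger effect at the one concentration tested and lower numbers for a weaker effect:

compound 1 `CCN(Cc1ccc(Br)cc1)c1cccc(C(=O)N2CCc3ccc(OS(N)(=O)=O)cc3C2)c1` gives 84.5%
compound 2 `NS(=O)(=O)Oc1ccc2c(c1)CN(C(=O)c1ccc(N3CCN(Cc4ccccc4)CC3)cc1)CC2` gives 75.8%
compound 3 `CCN(Cc1ccc(Br)cc1)c1ccc(C(=O)N2CCc3ccc(OS(N)(=O)=O)cc3C2)cc1` gives 95.9%

Compound 1 stands second of the three numbers in this assay. Its nearest neighbour is compound 2, whose number lies within the usual scatter of that of compound 1, so no order between the two can be read. Compound 3 lies higher than compound 1 by a gap beyond the scatter. All three share the same core with the sulfamate, and all three keep a large, ring-bearing amino substituent on the benzoyl part.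

Compound 4 `CCCN(CCC)c1cccc(C(=O)N2CCc3ccc(OS(N)(=O)=O)cc3C2)c1` has not yet been measured in this assay. It differs from compound 1 in one place: dipropylamino in place of (4-bromobenzyl)(ethyl)amino on an aromatic carbon. Among the compounds with values here, the substituent that enters is smaller and carries no ring, and no measured pair in the set tests a change of this kind, so the size of the step is open.

Compound 4 is expected to lie lower than compound 1, with a step of a number 19.5 percentage points lower from compound 1 to compound 4 (beyond the scatter), estimated because compound 1 gives 84.5% with the larger substituent in place. For compound 4 in this assay the estimate is 65%, with a range from 40% to 85%.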

Compound 4, a percentage reported as inhibition, at one concentration (the size of the read-out at that concentration, not a potency): 54.8%
Compound 4: the middle estimate sits 10.2 percentage points above what was measured, within the range that was stated.
By their numbers in this assay, from the lowest: compound 4; then compounds 2 and 1 (each within the scatter of the next); then compound 3.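

In this assay, within the data shown here, dipropylamino in place of (4-bromobenzyl)(ethyl)amino on an aromatic carbon, meta to a large group, gives a number 29.7 percentage points lower from compound 1 to compound 4 (beyond the scatter) and is the only single-place step in the set. This position is therefore not indifferent to the nature of the amino substituent: with the shared core unchanged and an amino nitrogen still attached at the same place, the substituent with no ring goes with the lower number. No measurement shown gives a reason for this step.

The compounds shown do not separate the loss of the aromatic ring from the loss of the bromine or from the change in the alkyl chains. A plain benzyl group with ethyl on the same nitrogen, or dibutylamino at this position, would be needed to tell these apart.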